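This account rests on a few compounds, and the source may have more. Where it says the series, first, only, none or still open, it means among the compounds named here.

Working notes on the series. Compound 1 `O=C(c1ccc(C(F)(F)F)cc1)N1CCC(NS(=O)(=O)c2cc(S(=O)(=O)c3ccccc3)ccc2C(F)(F)F)CC1` gives 400 nM in an assay on isolated protein for displacement of a labelled ligand from secreted frizzled-related protein 1 (Homo sapiens), read by fluorescence polarization, with a stated time of 30 min; a higher number here means a weaker inhibitor, a lower number a stronger inhibitor. Compound 2 `O=C(c1ccccn1)N1CCC(NS(=O)(=O)c2cc(S(=O)(=O)c3ccccc3)ccc2C(F)(F)F)CC1` gives 60 nM, and compound 3 `O=C(c1ccc(Cl)nc1)N1CCC(NS(=O)(=O)c2cc(S(=O)(=O)c3ccccc3)ccc2C(F)(F)F)CC1` gives 110 nM. Among the three numbers compound 3 stands second highest: the nearer step is a 1.8-fold higher number from compound 2 to compound 3 (0.26 log units; within the scatter), the further step is a 3.6-fold lower number from compound 1 to compound 3 (0.56 log units; beyond the scatter). The other step measured so far is a 6.7-fold lower number from compound 1 to compound 2 (0.82 log units; beyond the scatter).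

Compound 4 `N#Cc1cccc(S(=O)(=O)N2CCC(NS(=O)(=O)c3cc(S(=O)(=O)c4ccccc4)ccc3C(F)(F)F)CC2)c1` has not been measured. It differs from compound 3 in that ((3-cyanophenyl)sulfonyl in place of (6-chloropyridin-3-yl)carbonyl on an amine nitrogen in a ring). Within the data shown here, none of the measured steps touches this place: all three exchange the aryl group on the carbonyl carbon and leave the carbonyl itself in place, and the changes seen there were modest, as a 6.7-fold lower number from compound 1 to compound 2 (0.82 log units; beyond the scatter) and a 3.6-fold lower number from compound 1 to compound 3 (0.56 log units; beyond the scatter) show. Among the measured compounds shown here, no step in the data tells what the exchange of the carbonyl for a sulfonyl does. The expectation therefore rests on the narrow spread of the three numbers, with wide uncertainty. Compound 4 is expected to give 150 nM in this assay, within a range of 40 nM to 600 nM. That estimate means a step of a 1.4-fold higher number from compound 3 to compound 4 (0.13 log units; within the scatter), expected to stay near the scatter.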

Compound 4, half-maximal inhibitory concentration: 90 nM
Beside the measured number, compound 4's estimate is 1.7-fold (0.22 log units) above it, and the stated range covers the measured number.
By their numbers in this assay, from the lowest: compounds 2, 4 and 3 (each within the scatter of the next); then compound 1.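

At this position on the amine nitrogen in a ring, the carbonyl is not needed to keep the number in the range of compound 2 and compound 3 in this assay: the exchange for (3-cyanophenyl)sulfonyl gives a 1.2-fold lower number from compound 3 to compound 4 (0.09 log units; within the scatter) and a 1.5-fold higher number from compound 2 to compound 4 (0.18 log units; within the scatter) with the larger group in place. The sulfonyl compound also falls with these two pyridine amides and apart from the 4-(trifluoromethyl)phenyl amide, with a 4.4-fold lower number from compound 1 to compound 4 (0.65 log units; beyond the scatter) as the step beyond the scatter. Nothing at hand explains this tolerance of the exchange.

As far as these compounds go, in each of these steps the linking group and the aryl group change together, so the effect of the sulfonyl alone stays open. Also open, from the compounds shown here alone, is how a sulfonyl bearing a longer alkyl chain, or an aryl group carrying an amine or a carboxylic acid, would read here.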